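The source may report more compounds than this note shows. Statements on the series, on what has been measured and on what is new or still open speak of the compounds shown alone.

Series notes. Compound 1 `CC(C)c1[nH]cnc1/C=c1\[nH]c(=O)/c(=C/c2cccc(Oc3ccc(F)cc3)c2)[nH]c1=O` is the reference; in a functional assay on NCI-H460 cells (Homo sapiens) for cytotoxicity, read by MTT assay, with a stated time of 72 h (on this read-out lower numbers stand for stronger inhibition and higher numbers for weaker inhibition), compound 1 gives 8.8 nM. Compound 2 `O=c1[nH]/c(=C\c2ncc[nH]2)c(=O)[nH]/c1=C\c1cccc(Oc2ccc(F)cc2)c1` carries 1H-imidazol-2-yl on the double-bonded chain carbon bound to an aromatic carbon. In this assay compound 2 reaches > 1000 nM, which is a limit of the assay and not a number. The single measured step, an at least 110-fold higher number from compound 1 to compound 2 (2.05 log units; beyond the scatter), is large and runs toward weaker inhibition; its end point is fixed by the limit of > 1000 nM in this assay, at which 1 of the 2 values shown sits, so compound 2 stands at the top of the numbers shown with no true value known. Compound 3 `O=c1[nH]/c(=C\c2nc3ccccc3[nH]2)c(=O)[nH]/c1=C\c1cccc(Oc2ccc(F)cc2)c1` is not yet measured. Change: 1H-benzimidazol-2-yl in place of 1H-imidazol-2-yl on a double-bonded chain carbon bound to an aromatic carbon. Going by the values given here, no measured step covers 1H-benzimidazol-2-yl; the only guide is the loss along an at least 110-fold higher number from compound 1 to compound 2 (2.05 log units; beyond the scatter) when 5-isopropyl-1H-imidazol-4-yl gave way to 1H-imidazol-2-yl, and compound 3 adds a six-membered aromatic ring of carbon only onto that five-membered ring instead. The step is expected as an at least 1.6-fold lower number from compound 2 to compound 3 (0.22 log units; that floor lies within the scatter), toward stronger inhibition, with wide uncertainty since compound 2 is a limit. For compound 3 the estimate in this assay is 600 nM, range 100 nM to 3000 nM.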

Compound 3, half-maximal inhibitory concentration: > 1000 nM
Compound 3: no number, only a limit (the forecaster's own chance of this, stated with the estimate: 45%); middle value at least 1.6-fold (0.22 log units) away from the limit.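

In this assay compound 3 gives > 1000 nM, which is a limit of the assay and not a number. With 1H-benzimidazol-2-yl in place of 5-isopropyl-1H-imidazol-4-yl on the double-bonded chain carbon bound to an aromatic carbon, the series shows an at least 110-fold higher number from compound 1 to compound 3 (2.05 log units; beyond the scatter), so the loss seen earlier is not confined to 1H-imidazol-2-yl but also holds for the larger group. The step between the two limit compounds cannot be read, so the added six-membered aromatic ring of carbon only is known not to bring a measured number back into view, while any smaller change it makes stays hidden: the limit of > 1000 nM in this assay, at which 2 of the 3 values shown sit.

The compounds shown leave open whether the loss follows the absence of the isopropyl group or the different attachment of the ring, as the names 5-isopropyl-1H-imidazol-4-yl and 1H-imidazol-2-yl differ in both. Also open, on these data alone, is whether a methyl group or an amine on 1H-imidazol-2-yl would give a number rather than a limit.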